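Replacing a Bicyclic Amine Substituent with an Open Chain

A few compounds are considered here, and "the series" means these few. Any claim that something is new, unique, unknown or untested is made for them only; others in the source may bear on it.

Going by the values given here, compound 1 `c1ccc2c(c1)CCC2NC1CCN(CCCc2c[nH]c3ccc(-n4cnnc4)cc23)CC1` is one of three compounds measured in an assay on CHO cells for displacement of a labelled ligand from 5-hydroxytryptamine receptor 1D (Homo sapiens) (on this read-out lower numbers stand for stronger inhibition and higher numbers for weaker inhibition), where compound 1 gives 8.9 nM. Compound 2 `CC(=O)Nc1ccc(CNC2CCN(CCCc3c[nH]c4ccc(-n5cnnc5)cc34)CC2)cc1` gives 3 nM, a lower number, and compound 3 `OC[C@H](NC1CCN(CCCc2c[nH]c3ccc(Cn4cncn4)cc23)CC1)c1ccccc1` gives 23 nM, a higher number, so compound 1 holds the second highest number of the three. Compound 4 `CC(C)=CCN(C)C1CCN(CCCc2c[nH]c3ccc(-n4cnnc4)cc23)CC1` is not yet measured; it differs from compound 1 as follows: methyl(3-methylbut-2-en-1-yl)amino in place of (2,3-dihydro-1H-inden-1-yl)amino on a saturated ring carbon. Among the compounds with values here, the only measured step at an amine nitrogen is a 3.0-fold lower number from compound 1 to compound 2 (0.47 log units; beyond the scatter), where one ring-bearing group replaced another. Within the data shown here, no measured step removes all rings from that position or adds a methyl to the amine, so the guidance is loose. A small step is expected, leaning toward a slightly higher number: compound 4 is estimated at 15 nM, within 4 nM to 60 nM, which would be the step of a 1.7-fold higher number from compound 1 to compound 4 (0.23 log units; within the scatter).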

Compound 4, half-maximal inhibitory concentration: 0.5 nM
Estimate against measurement, compound 4: 30-fold (1.48 log units) above; measured number below the stated range.
By their numbers in this assay, from the lowest: compound 4; then compound 2; then compound 1; then compound 3.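

Open-chain methyl(3-methylbut-2-en-1-yl)amino, with no ring and no hydrogen-bond donor, gives an 18-fold lower number from compound 1 to compound 4 (1.25 log units; beyond the scatter), so a ring in this substituent is not needed for a low number. Going by these compounds alone, the only earlier step at this amine swapped one ring-bearing group for another. No measurement shown here explains the gain.

Going by these compounds, the change removes the rings, adds a methyl on the nitrogen and brings in a double bond all at once, so their separate shares remain unknown. The unmethylated 3-methylbut-2-en-1-ylamino group and the saturated 3-methylbutyl chain would separate them.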